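Thiazole in Place of Thiophene on a Weakly Active Core

A few compounds are considered here, and "the series" means these few. Any claim that something is new, unique, unknown or untested is made for them only; others in the source may bear on it.

Three measured compounds share one core and differ only in the aromatic group attached to it. Compound 1 `CSc1cccc(Nc2nc(-c3ccc(F)cc3)cs2)c1` gives 27000 nM in an assay on CFBE41o cells for positive allosteric modulation of Cystic fibrosis transmembrane conductance regulator variant F508del (Homo sapiens), with stated times of 30 min and 24 h; a lower number here means that less compound is needed, a higher number that more compound is needed for the effect. Compound 2 `CSc1cccc(Nc2nc(-c3cccc(Cl)c3)cs2)c1` gives 53000 nM in this assay, and the step of a 2.0-fold higher number from compound 1 to compound 2 (0.29 log units; within the scatter) shows that exchanging one aromatic group for another here changed little. Compound 3 `CSc1cccc(Nc2nc(-c3cccs3)cs2)c1` carries a thiophen-2-yl group and is recorded as "not active" (no number reported) in this assay, so no number marks where it stands; the only statement is that no effect was seen.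

Compound 4 `CSc1cccc(Nc2nc(-c3nccs3)cs2)c1` differs from compound 3 in one place: 1,3-thiazol-2-yl in place of thiophen-2-yl on an aromatic carbon. Going by the values given here, no measured step tests this exchange; the one recorded step, from compound 1 to compound 2, concerns other groups and was small. Compound 3 gives no number to start from, so the expectation rests on the weak values of compounds 1 and 2 and on the absence of activity for compound 3. Compound 4 is therefore expected to be weak at best, with an estimated value in this assay around 60000 nM, within a range from 20000 nM to 200000 nM, and with a real chance that again no activity is reported.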

Compound 4, half-maximal effective concentration: 9500 nM
Beside the measured number, compound 4's estimate is 6.3-fold (0.80 log units) above it; the whole stated range lies above it.
By their numbers in this assay, from the lowest: compound 4; then compounds 1 and 2 (each within the scatter of the next).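

In this assay the 1,3-thiazol-2-yl group at this position brings a 5.6-fold lower number from compound 2 to compound 4 (0.75 log units; beyond the scatter) and a 2.8-fold lower number from compound 1 to compound 4 (0.45 log units; beyond the scatter) and so does modestly better than the 3-chlorophenyl and 4-fluorophenyl groups. Compound 3 has no number, so the exchange of thiophen-2-yl for 1,3-thiazol-2-yl cannot be given a size, yet this single exchange of one ring for another separates a compound recorded as not active from one with a measurable value. Nothing given here bears on the reason for this difference.

From the compounds shown here alone, whether other groups at this position, such as a pyridin-2-yl ring, a simple amine or a carboxylic acid, would lower the number further remains open. Also open, going by these compounds, is whether the 1,3-thiazol-2-yl group would keep its advantage with changes elsewhere on the shared core.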